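A few compounds are considered here, and "the series" means these few. Any claim that something is new, unique, unknown or untested is made for them only; others in the source may bear on it.

Compound 1, `Cc1cc(=O)oc2cc(OCC(O)CN3CCC(C(N)=O)CC3)ccc12`, gives > 100000 nM in an ADME assay on A549 cells (Homo sapiens) for cytotoxicity, read by CellTiter-Glo; a lower number here means that less compound is tolerated, a higher number that more compound is tolerated; this is a limit of the assay, not a number.
Compound 2, `Cc1c(Cc2ccc(F)cc2)c(=O)oc2cc(OCC(O)CN3CCC(C(N)=O)CC3)ccc12`, gives 89300 nM in this assay.
Compound 3, `Cc1c(Cc2ccccc2C(F)(F)F)c(=O)oc2cc(OCC(O)CN3CCC(C(N)=O)CC3)ccc12`, gives > 100000 nM in this assay; this too is a limit.

Among these three, compound 2 stands as the only number shown; the other two values are limits, and the limit of > 100000 nM in this assay, at which 2 of the 3 values shown sit, marks where they sit. Compound 4, `COc1ccccc1-c1ccc(Cc2c(C)c3ccc(OCC(O)CN4CCC(C(N)=O)CC4)cc3oc2=O)cc1`, differs from compound 2 in one place: 2-methoxyphenyl in place of fluoro on an aromatic carbon. Among the measured compounds shown here, two measured steps bear on this change. The step of an at least 1.1-fold lower number from compound 1 to compound 2 (0.04 log units; that floor lies within the scatter) and the step of an at least 1.1-fold higher number from compound 2 to compound 3 (0.04 log units; that floor lies within the scatter) both have floors that lie within the scatter, so neither shows a movement that can be read as real. The step that the two limits leave unreadable from compound 1 to compound 3 cannot be read at all. With no clear movement in any of these, compound 4 is expected to stay close to compound 2, and the step of a 1.3-fold lower number from compound 2 to compound 4 (0.11 log units; within the scatter) is estimated to lie within the scatter. Compound 4 is therefore estimated at 70000 nM, with a range from 25000 nM to 200000 nM.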

Compound 4, half-maximal cytotoxic concentration: 91600 nM
Compound 4: the middle estimate sits 1.3-fold (0.12 log units) below what was measured; the measured number falls inside the stated range.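

Among the compounds shown here, replacing the fluoro with 2-methoxyphenyl gives a 1.0-fold higher number from compound 2 to compound 4 (0.01 log units; within the scatter), the first step in this set with real numbers at both ends and not a limit at either. In this assay, compound 2 and compound 4 therefore cannot be told apart, even though the entering group brings 8 heavy atoms and a six-membered aromatic ring of carbon only to this position, para to a large group. This one step covers a single swap, and some of the values are still not numbers: the limit of > 100000 nM in this assay, at which 2 of the 4 values shown sit.

From the compounds shown here alone, whether an amine or a carboxylic acid at this position would also leave the number within the scatter remains open. So does whether any group here could produce a clear drop in the number, since no step shown does so.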